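A few compounds are considered here, and "the series" means these few. Any claim that something is new, unique, unknown or untested is made for them only; others in the source may bear on it.

Compound 1 `O=[N+]([O-])c1c(CS(=O)(=O)c2ccccc2)nc2c(-c3ccc(CO)cc3)cc(Cl)cn12`: 13100 nM
Compound 2 `O=[N+]([O-])c1c(CS(=O)(=O)c2ccccc2)nc2c(-c3cccc(F)c3)cc(Cl)cn12`: > 12500 nM

In an ADME assay on HepG2 cells (Homo sapiens) for cytotoxicity, read by MTT assay, with a stated time of 72 h (a higher number here means that more compound is tolerated, a lower number that less compound is tolerated), compound 1 gives 13100 nM. Compound 2 has no exact number, and its > 12500 nM is a limit of the assay. Compound 2 therefore stands at the limit of > 12500 nM in this assay, at which 1 of the 2 values shown sits.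

Compound 3 `O=[N+]([O-])c1c(CS(=O)(=O)c2ccccc2)nc2c(-c3ccccc3F)cc(Cl)cn12` has the same atoms as compound 2, joined differently: 2-fluorophenyl in place of 3-fluorophenyl on an aromatic carbon. The 2-fluorophenyl takes the place of the 3-fluorophenyl on the same aromatic carbon of the shared core.

Among the compounds with values here, the only measured step that bears on this is a step that the limit leaves unreadable from compound 1 to compound 2. It offers no size to carry forward, and it exchanges a different pair of groups. Within the data shown here, no measured pair tests a move of the fluorine around the ring.

The expectation is therefore no step beyond the usual scatter in this assay, in either direction. This expectation rests on compound 2 with its > 12500 nM, which is again only a limit. The expected change is a step that the limit leaves unreadable from compound 2 to compound 3. The estimate for compound 3 is 14000 nM, with an expected range from 7000 nM to 30000 nM.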

Compound 3, half-maximal cytotoxic concentration: > 3900 nM
Compound 3 was reported as a limit (the forecaster's own chance of this, stated with the estimate: 50%); the middle value is on the limit's open side.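

Compound 3 gives > 3900 nM, which is a limit of the assay and not a number. Within the data shown here, with compound 2 also reported only as a limit, no step among compound 1, compound 2 and compound 3 can be read. As far as these compounds go, whether 2-fluorophenyl and 3-fluorophenyl differ in how much compound the cells tolerate stays open.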